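Turning One Double Bond from Z to E

The compounds below may be only part of what the source reports. "The series", "measured", "known", "first", "only" and "open" are said of these compounds alone.

In a functional assay on MCF7 cells (Homo sapiens) for cytotoxicity (on this read-out higher numbers stand for an effect only at larger amounts of compound and lower numbers for an effect already at smaller amounts), compound 1 (`CCOc1ccc(/C=C/c2cc(OC)c(OC)c(OC)c2)cc1`) gives 7.5 uM, compound 2 (`COc1cc(/C=C/c2ccc(SC)cc2)cc(OC)c1OC`) gives 5.9 uM and compound 3 (`CCCOc1ccc(/C=C\c2cc(OC)c(OC)c(OC)c2)cc1`) gives 6.6 uM, so all three lie within the usual scatter of one another. Compound 4 (`CCCOc1ccc(/C=C/c2cc(OC)c(OC)c(OC)c2)cc1`) differs from compound 3 in geometry alone: the two compounds have the same atoms and bonds and differ only in configuration as drawn: 1 of 1 stereo elements differ; a double bond is drawn Z in compound 3 and E in compound 4. Going by the values given here, no measured step tests such a switch. Among the compounds with values here, the only measured step, a 1.3-fold lower number from compound 1 to compound 2 (0.10 log units; within the scatter), replaces ethoxy with methylsulfanyl and offers indirect guidance at best. Still, compound 1 and compound 2, both drawn E, sit level with compound 3, so no shift beyond the scatter is expected in this assay. The expected change is a 1.1-fold higher number from compound 3 to compound 4 (0.06 log units; within the scatter). For compound 4, the estimated value is 7.5 uM, within a range of 3.5 uM to 16 uM.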

Compound 4, concentration for half-maximal effect: 12.5 uM
The estimate for compound 4 lay 1.7-fold (0.22 log units) below the measured number, within the range that was stated.
By their numbers in this assay, from the lowest: compounds 2, 3, 1 and 4 (each within the scatter of the next, the first and the last beyond it).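

Compound 3 and compound 4 give the first direct test of the double-bond geometry in this assay, and the switch from Z to E gives a 1.9-fold higher number from compound 3 to compound 4 (0.28 log units; within the scatter). Nothing else can account for this step: the fact that compounds 3 and 4 differ only in the configuration as drawn. Among the E compounds, methyl in place of hydrogen on the chain gives a 1.7-fold higher number from compound 1 to compound 4 (0.22 log units; within the scatter), while propoxy in place of methylsulfanyl gives a 2.1-fold higher number from compound 2 to compound 4 (0.33 log units; beyond the scatter), the only new step beyond the scatter.

As far as these compounds go, whether the same switch behaves alike with ethoxy or methylsulfanyl in place of propoxy stays open. So does what a butoxy chain or an amine would give at this place.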